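A few compounds are considered here, and "the series" means these few. Any claim that something is new, unique, unknown or untested is made for them only; others in the source may bear on it.

Three compounds have been measured in a functional assay on 143B cells (Homo sapiens) for antiproliferative activity, read by MTT assay, with a stated time of 48 h; on this read-out lower numbers stand for stronger inhibition and higher numbers for weaker inhibition:

compound 1, `O=C(/C=C/c1cccc(NC(=O)c2ccccc2Br)c1)c1nc2ccccc2[nH]1`: compound 1 gives 6050 nM
compound 2, `O=C(Nc1cccc(/C=C/C(=O)c2nc3ccccc3[nH]2)c1)c1ccc(Br)cc1`: compound 2 gives 7310 nM
compound 3, `Cc1ccccc1C(=O)Nc1cccc(/C=C/C(=O)c2nc3ccccc3[nH]2)c1`: compound 3 gives 8290 nM

Compound 3 returns the highest of the three numbers, but its separation from the others is small: the nearest is compound 2, with a 1.1-fold higher number from compound 2 to compound 3 (0.05 log units; within the scatter), and the furthest is compound 1, with a 1.4-fold higher number from compound 1 to compound 3 (0.14 log units; within the scatter). Nothing among the three stands apart beyond the scatter.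

Compound 4, `COc1ccc(C(=O)Nc2cccc(/C=C/C(=O)c3nc4ccccc4[nH]3)c2)cc1`, differs from compound 3 in one place: 4-methoxyphenyl in place of 2-methylphenyl on a carbonyl carbon. Among the compounds with values here, two measured steps bear on this exchange, since each also swaps the aryl group on that carbonyl carbon: a 1.2-fold higher number from compound 1 to compound 2 (0.08 log units; within the scatter) and a 1.1-fold higher number from compound 2 to compound 3 (0.05 log units; within the scatter). Both fall within the scatter, so the aryl exchanges seen so far have not moved this assay in any resolved direction.

Compound 4 is therefore expected to land near compound 3, with a 1.1-fold lower number from compound 3 to compound 4 (0.03 log units; within the scatter) expected to stay within the scatter. The estimate for compound 4 in this assay is 7800 nM, with an expected range from 3500 nM to 17500 nM.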

Compound 4, half-maximal inhibitory concentration: 6330 nM
Estimate against measurement, compound 4: 1.2-fold (0.09 log units) above, within the range that was stated.
By their numbers in this assay, from the lowest: compounds 1, 4, 2 and 3 (each within the scatter of the next).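

In this assay, 4-methoxyphenyl on the carbonyl carbon whose other neighbour is the amide-type nitrogen stays within the scatter of all three earlier aryl groups, with a 1.3-fold lower number from compound 3 to compound 4 (0.12 log units; within the scatter) and a 1.2-fold lower number from compound 2 to compound 4 (0.06 log units; within the scatter) and a 1.0-fold higher number from compound 1 to compound 4 (0.02 log units; within the scatter). The earlier compounds shown here varied only bromo and methyl on this aryl group, whereas compound 4 brings in an oxygen and one hydrogen-bond acceptor, and even this exchange gives no resolved step. No measurement at hand offers an explanation for this flat result.

The compounds shown leave open whether an amine or a carboxylic acid on this aryl group would give a step beyond the scatter. They also leave open whether a longer alkyl chain in place of the whole aryl group on the carbonyl carbon would do so.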